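Propylcarbamoyl for hydroxymethyl at the furan carbon

This account rests on a few compounds, and the source may have more. Where it says the series, first, only, none or still open, it means among the compounds named here.

Among the measured compounds shown here, compound 2 `Cc1cccc(Nc2ncnc3oc(C)c(CO)c23)c1` holds the only plain number in the set: in a functional assay on MCF7 cells (Homo sapiens) for cytotoxicity, read by MTT assay, with a stated time of 72 h (on this read-out lower numbers stand for stronger inhibition and higher numbers for weaker inhibition), compound 2 gives 17000 nM. Compound 1 `CCOC(=O)c1c(C)oc2ncnc(Nc3cccc(C)c3)c12` sits at a limit of this assay, giving > 1000000 nM. Compound 3 `CCOC(=O)c1c(C)oc2ncnc(Nc3cccc(Br)c3)c12` likewise sits at a limit of this assay, giving > 1000000 nM. Compound 4 `CCCNC(=O)c1c(C)oc2ncnc(Nc3cccc(C)c3)c12` is not yet measured; it differs from compound 2 by propylcarbamoyl in place of hydroxymethyl on an aromatic carbon.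

For the measured compounds named here, no measured step exchanges hydroxymethyl for a carbamoyl group. Going by the values given here, the one step that bears on the position runs the other way: an at least 58-fold lower number from compound 1 to compound 2 (1.76 log units; beyond the scatter), so moving off ethoxycarbonyl onto hydroxymethyl is what brought the number down from the limit. The step that the two limits leave unreadable from compound 1 to compound 3 touches the aryl amine, not this carbon, and the limit of > 1000000 nM in this assay, at which 2 of the 3 values shown sit, keeps both of its ends unreadable. Propylcarbamoyl puts a carbonyl back onto the carbon where compound 1 carried one, so the expectation is a return toward the weaker end, with a real chance that only a limit is reported.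

For compound 4 the expected step is an 18-fold higher number from compound 2 to compound 4 (1.25 log units; beyond the scatter). Compound 4 is therefore estimated at 300000 nM, with a range from 30000 nM to 1000000 nM.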

Compound 4, half-maximal inhibitory concentration: > 1000000 nM
Compound 4 was reported as a limit (the forecaster's own chance of this, stated with the estimate: 40%); at least 3.3-fold (0.52 log units) between middle value and limit.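

In this assay, propylcarbamoyl in place of hydroxymethyl on this aromatic carbon gives a large change in the weaker direction: an at least 58-fold higher number from compound 2 to compound 4 (1.76 log units; beyond the scatter). Until now, ethoxycarbonyl was the only group set against hydroxymethyl at this carbon; a second carbonyl-bearing group now ends the same way, leaving compound 2, with hydroxymethyl, as the only compound shown that has a plain number. The step between compound 1 and compound 4, propylamino in place of ethoxy on the carbonyl carbon, cannot be read, and the same holds for every other pair of limits in the set: the limit of > 1000000 nM in this assay, at which 3 of the 4 values shown sit.

Still open, going by these compounds, is how far the plain number depends on hydroxymethyl itself, which an aminomethyl group, a methoxymethyl group or a carboxylic acid on this carbon would help to settle, as would a shorter amide such as unsubstituted carbamoyl. Also open, on these data alone, is the effect of bromo in place of methyl, as carried by compound 3, which could be read only in a compound that also keeps hydroxymethyl on this carbon and gives a plain number.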